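This account rests on a few compounds, and the source may have more. Where it says the series, first, only, none or still open, it means among the compounds named here.

In an ADME assay on microsomes from liver (Homo sapiens) for metabolic stability, read by LC-MS, with a stated time of 40 min, tested at 0.5 uM (a lower number here means slower removal, a higher number faster removal of the compound), compound 1 `O=C(Nc1cccc(S(=O)(=O)C2CCCC2)c1)c1cccnc1N1CCC(F)(F)CC1` gives > 399 mL.min-1.g-1 as a limit of the assay and not a number. Compound 2 `CC(C)(CO)S(=O)(=O)c1cccc(NC(=O)c2cccnc2N2CCC3(CC2)CC3)c1` gives 154 mL.min-1.g-1 and compound 3 `CC(C)(C)NS(=O)(=O)c1cccc(NC(=O)c2ccc(NC3(CO)CC3)cc2N2CCC3(CC2)CC3)n1` gives 83 mL.min-1.g-1 and these two values lie within the scatter of each other. Compound 4 `CC(C)(C)NS(=O)(=O)c1cccc(NC(=O)c2cccnc2N2CCC3(CC2)CC3)c1` is not yet measured and differs from compound 2 by (tert-butyl)amino in place of 1-(hydroxymethyl)-1-methylethyl on a sulfonyl sulfur with (tert-butyl)amino in place of 1-(hydroxymethyl)-1-methylethyl on a sulfonyl sulfur. Compound 3 also bears (tert-butyl)sulfamoyl and gives 83 mL.min-1.g-1 so no step beyond the scatter is expected in this assay for this change. The estimated step of a 1.0-fold higher number from compound 2 to compound 4 (0.02 log units; within the scatter) stays within the scatter. Compound 4 is estimated at 160 mL.min-1.g-1 with an expected range from 75 mL.min-1.g-1 to 350 mL.min-1.g-1 in this measurement.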

Compound 4, intrinsic clearance in microsomes: > 399 mL.min-1.g-1
Compound 4 ended at the assay's limit (the forecaster's own chance of this, stated with the estimate: 10%); middle value at least 2.4-fold (0.39 log units) away from the limit.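

In this assay, replacing 1-(hydroxymethyl)-1-methylethyl with (tert-butyl)amino on a sulfonyl sulfur gives the first step read at this place, and it is not neutral: an at least 2.5-fold higher number from compound 2 to compound 4 (0.41 log units; beyond the scatter). The value of compound 4 is a limit of the assay and not a number. The full size of the step therefore stays unread: the limit of > 399 mL.min-1.g-1 in this assay, at which 2 of the 4 values shown sit.

The compounds shown leave open how a longer chain carrying the hydroxyl, or a carboxylic acid, on the sulfonyl sulfur would read. They also leave open whether an amine there would give a number clear of the limit.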